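Chloro to difluoro on the urea aryl of compound 4

The compounds below may be only part of what the source reports. "The series", "measured", "known", "first", "only" and "open" are said of these compounds alone.

Compound 3 `CC(C)N(CCN(C(=O)Nc1cccc(Cl)c1)C1CC[C@]2(c3cccc(C#N)c3)CC2C1)C(C)C` gives 6 nM in a functional assay for antagonist activity at melanin-concentrating hormone receptor 1 (Homo sapiens) (a higher number here means a weaker inhibitor, a lower number a stronger inhibitor), the second highest of the three numbers recorded. Compound 2 `CC(C)N(CCN(C(=O)Nc1cccc(F)c1)C1CC[C@]2(c3cccc(C#N)c3)CC2C1)C(C)C` gives 2.1 nM in this assay. Compound 1 `N#Cc1cccc([C@]23CCC(N(CCN4CC[C@@H](O)C4)C(=O)Nc4cc(F)cc(F)c4)CC2C3)c1` carries a different amine but the same 3,5-difluorophenyl group that compound 4 will carry; in this assay compound 1 gives 15 nM. Compound 4 `CC(C)N(CCN(C(=O)Nc1cc(F)cc(F)c1)C1CC[C@]2(c3cccc(C#N)c3)CC2C1)C(C)C` differs from compound 3 by 3,5-difluorophenyl in place of 3-chlorophenyl on an amide-type nitrogen. The one measured step that bears on this change is a 2.9-fold higher number from compound 2 to compound 3 (0.46 log units; beyond the scatter), so the direction from chloro back toward fluoro on that ring has been favourable here, though whether the second fluorine on the ring adds anything is not shown by any pair of measured compounds. He therefore expects compound 4 to fall somewhat lower than compound 3, with a step of a 1.7-fold lower number from compound 3 to compound 4 (0.23 log units; within the scatter) that may not clear the scatter. His estimate for compound 4 in this assay is 3.5 nM, with a range from 1.2 nM to 10 nM.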

Compound 4, inhibition constant: 4.5 nM
Compound 4: middle estimate off by 1.3-fold (0.11 log units), on the low side; measured number inside the range.
By their numbers in this assay, from the lowest: compound 2; then compounds 4 and 3 (each within the scatter of the next); then compound 1.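

In this assay, 3,5-difluorophenyl in place of 3-chlorophenyl on the amide-type nitrogen gives a 1.3-fold lower number from compound 3 to compound 4 (0.12 log units; within the scatter), so these two groups cannot be told apart here. Going by these compounds alone, the second fluorine, untested by the earlier pairs, now has a reading: fluoro in place of hydrogen on an aromatic carbon gives a 2.1-fold higher number from compound 2 to compound 4 (0.33 log units; beyond the scatter), a modest loss rather than a gain. With the 3,5-difluorophenyl group held fixed, diisopropylamino in place of 3-hydroxypyrrolidin-1-yl gives a 3.3-fold lower number from compound 1 to compound 4 (0.52 log units; beyond the scatter), so the amine on the chain also moves the number.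

Nothing shown explains any of these steps. Within the data shown here, also open is whether a methoxy group or a bromine on that ring would match the single fluoro of compound 2, and whether that fluoro would keep its standing alongside the 3-hydroxypyrrolidin-1-yl group.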